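Aryl amide swap on the tolyl sulfonamide core

The compounds below may be only part of what the source reports. "The series", "measured", "known", "first", "only" and "open" are said of these compounds alone.

Compound 2 `Cc1ccccc1C(=O)NCc1ccc(CNS(=O)(=O)c2ccccc2)cc1` gives 1 nM in an assay on MDA-MB-231 cells for binding affinity to C-X-C chemokine receptor type 4 (Homo sapiens), read by immunofluorescence and microscopy, with stated times of 10 min and 30 min; on this read-out lower numbers stand for an effect already at smaller amounts and higher numbers for an effect only at larger amounts of compound. Compound 1 `O=C(NCc1ccc(CNS(=O)(=O)c2ccccc2)cc1)c1cccnc1` carries the change pyridin-3-yl in place of 2-methylphenyl on a carbonyl carbon and gives 10 nM in this assay; the step is a 10-fold higher number from compound 2 to compound 1 (1.00 log units; beyond the scatter). Compound 3 `Cc1ccc(S(=O)(=O)NCc2ccc(CNC(=O)c3ccccc3C)cc2)cc1` differs from compound 2 in its core by methyl in place of hydrogen on an aromatic carbon. In this assay compound 3 gives 100 nM; the step is a 100-fold higher number from compound 2 to compound 3 (2.00 log units; beyond the scatter). Compound 4 `Cc1ccc(S(=O)(=O)NCc2ccc(CNC(=O)c3cccnc3)cc2)cc1` is not yet measured; it relates to compound 3 by pyridin-3-yl in place of 2-methylphenyl on a carbonyl carbon. The place of this change is described in the same words for both pairs, so it is the same change made on the other core. Going by the values given here, the only measured guide for this change is the step of a 10-fold higher number from compound 2 to compound 1 (1.00 log units; beyond the scatter). The change from compound 3 to compound 4 is expected to be about as large as that single measured step. Compound 4 is therefore expected to give 1000 nM in this assay, within 300 nM to 3000 nM. The estimated step amounts to a 10-fold higher number from compound 3 to compound 4 (1.00 log units; beyond the scatter).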

Compound 4, effective concentration (reported as EC, without a stated level of effect): > 1000 nM
Compound 4 gave a limit, no number (the forecaster's own chance of this, stated with the estimate: 10%); the middle value sits exactly at the limit.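

In this assay compound 4 gives > 1000 nM, which is a limit of the assay and not a number. Pyridin-3-yl in place of 2-methylphenyl gives an at least 10-fold higher number from compound 3 to compound 4 (1.00 log units; beyond the scatter), the same direction as on the other core, but the size of this step is only bounded: the same change on two cores in this assay, a 10-fold higher number (1.00 log units; beyond the scatter) from compound 2 to compound 1 and an at least 10-fold higher number (1.00 log units; beyond the scatter) from compound 3 to compound 4; the limit leaves it open whether they differ Methyl in place of hydrogen on an aromatic carbon likewise gives an at least 100-fold higher number from compound 1 to compound 4 (2.00 log units; beyond the scatter), so the direction carries over while equal size remains unshown: the same change on two cores in this assay, a 100-fold higher number (2.00 log units; beyond the scatter) from compound 2 to compound 3 and an at least 100-fold higher number (2.00 log units; beyond the scatter) from compound 1 to compound 4; the limit leaves it open whether they differ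

The compounds shown leave open how the series reads with an aliphatic amine on the carbonyl carbon in place of either aromatic ring. They also leave open whether a methoxy group on the aromatic carbon reads as methyl does.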